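A few compounds are considered here, and "the series" means these few. Any claim that something is new, unique, unknown or untested is made for them only; others in the source may bear on it.

Measured compounds:
- compound 1, `CCc1ccc(Nc2cc(NC(=O)Nc3c(Cl)cccc3Cl)ncn2)cc1`: 31.5%
- compound 2, `CC(C)(C)c1ccc(Nc2cc(NC(=O)Nc3c(Cl)cccc3Cl)ncn2)cc1`: 22%
- compound 3, `COc1cc(NC(=O)Nc2cc(Nc3ccc(C(C)(C)C)cc3)ncn2)cc(OC)c1`: 17.5%

These three compounds were tested in a functional assay on NCI-H520 cells (Homo sapiens) for inhibition, read by MTT assay, with a stated time of 48 h, tested at 10 uM; on this read-out lower numbers stand for less inhibition and higher numbers for more inhibition at the one concentration tested (going by the name of the read-out). Compound 1 gives the highest of the three numbers, though its gap to compound 2, a number 9.5 percentage points lower from compound 1 to compound 2 (within the scatter), lies within the usual scatter, while its gap to compound 3 lies beyond it. The step of a number 4.5 percentage points lower from compound 2 to compound 3 (within the scatter) also stays within the scatter.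

Compound 4, `Cc1cc(F)cc(Nc2cc(NC(=O)Nc3c(Cl)cccc3Cl)ncn2)c1`, has not yet been measured. It differs from compound 1 by 3-fluoro-5-methylphenyl in place of 4-ethylphenyl on a nitrogen on an aromatic ring. Among the measured compounds shown here, the only measured step at the same place is the one from compound 1 to compound 2, which swapped one group on the same aromatic ring for another and changed the read-out by a number 9.5 percentage points lower from compound 1 to compound 2 (within the scatter), within the scatter. The step from compound 2 to compound 3 concerns a different part of the molecule and says little here. The expectation is therefore for no step beyond the scatter, estimated as a number 6.5 percentage points lower from compound 1 to compound 4 (within the scatter). Compound 4 is expected to give 25%, with a range from 10% to 40%.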

Compound 4, a percentage reported as inhibition, at one concentration (the size of the read-out at that concentration, not a potency): 60.5%
For compound 4 the middle estimate is 35.5 percentage points below the measured one, and the stated range ends below it.
By their numbers in this assay, from the lowest: compounds 3, 2 and 1 (each within the scatter of the next, the first and the last beyond it); then compound 4.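

In this assay, among the compounds shown here, the step of a number 29 percentage points higher from compound 1 to compound 4 (beyond the scatter) is the first change on this aromatic amine nitrogen to go beyond the usual scatter. The earlier change on the same ring, tert-butyl in place of ethyl, stayed within the scatter, so the result shows that the group on this nitrogen can shift the read-out clearly upward, here with 3-fluoro-5-methylphenyl in place of 4-ethylphenyl. No measurement at hand offers a reason for this rise.

Because this swap removes the ethyl group and brings in fluorine and methyl together, the compounds shown cannot separate what each of these groups contributes. They also leave open how the read-out would respond to other groups on this ring, such as an amine, a carboxylic acid or a longer chain like hexyl.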